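A few compounds are considered here, and "the series" means these few. Any claim that something is new, unique, unknown or untested is made for them only; others in the source may bear on it.

Measured compounds:
compound 1, `CC(=O)NCCN(C)c1cccc(OCCCCCCNC(=O)Oc2cccc(-c3ccccc3)c2)c1` — 21.4 nM
compound 2, `CC(=O)NCCN(C)c1cccc(OCCCCOc2cccc(OC(=O)NC3CCCCC3)c2)c1` — 34.7 nM

Both were tested in an assay on cells for displacement of a labelled ligand from melatonin receptor type 1A (Homo sapiens), using the Cheng-Prusoff equation, with a stated time of 90 min; on this read-out lower numbers stand for stronger inhibition and higher numbers for weaker inhibition. Compound 1 gives 21.4 nM and compound 2 gives 34.7 nM. Compound 1 carries the smaller of the two numbers recorded, but the gap to compound 2 lies within the usual scatter, so neither is read as the stronger and no order is claimed between them.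

Compound 3, `CC(=O)NCCN(C)c1cccc(OCCCCCCNC(=O)Oc2cccc(-c3cccc(C(N)=O)c3)c2)c1`, is not yet measured in this assay. Set against compound 1 it shows (carbamoyl in place of hydrogen on an aromatic carbon). Going by the values given here, no step between measured compounds covers a change of this kind: compound 2 differs from compound 1 in several places at once, so its number tells nothing about the carbamoyl in place of hydrogen on an aromatic carbon. The expectation for compound 3 therefore rests on compound 1 alone, with a wide range. A step from compound 1 to compound 3 of a 1.2-fold higher number from compound 1 to compound 3 (0.07 log units; within the scatter) is expected, that is, no change beyond the scatter in either direction. Compound 3 is estimated at 25 nM in this assay, within 8 nM to 80 nM.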

Compound 3, inhibition constant: 38.9 nM
For compound 3 the middle estimate is 1.6-fold (0.19 log units) below the measured one; measured number inside the range.
By their numbers in this assay, from the lowest: compounds 1, 2 and 3 (each within the scatter of the next).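

In this assay the change from phenyl to 3-carbamoylphenyl gives a 1.8-fold higher number from compound 1 to compound 3 (0.26 log units; within the scatter) and adds 3 heavy atoms, with 1 hydrogen-bond donor and 1 hydrogen-bond acceptor. Going by these compounds alone, this is the first single-place comparison, and it shows that carbamoyl can stand in place of hydrogen on this aromatic carbon, meta to a large group, with no change that can be told from the scatter. No measurement at hand accounts for the size of this step.

A single substituent at a single position leaves open whether an amine, a carboxylic acid or a nitrile on the same carbon would also stay within the scatter of compound 1, and whether carbamoyl on another carbon of that ring would do so. Within the data shown here, it also leaves open whether the step would hold with a longer chain or a shorter chain in place of the one in compound 1, or with carbamoyl added to the cyclohexyl compound, compound 2.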